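Replacing the charged group of compound 3 with cyano

A few compounds are considered here, and "the series" means these few. Any claim that something is new, unique, unknown or untested is made for them only; others in the source may bear on it.

Measured in a functional assay (Homo sapiens) for inhibition; a lower number here means a stronger inhibitor, a higher number a weaker inhibitor:
- compound 1 `COc1ccc(C(=O)/C=C/c2ccccc2F)c(OC)c1OC`: 11000 nM
- compound 2 `COc1ccc(C(=O)/C=C/c2cccc(F)c2)c(OC)c1OC`: 6400 nM
- compound 3 `COc1ccc(C(=O)/C=C/c2ccc([N+](C)(C)C)cc2)c(OC)c1OC`: 35000 nM

In this assay compound 3, at 35000 nM, has the highest number of the three, beyond the scatter from both others. Compound 4 `COc1ccc(C(=O)/C=C/c2ccc(C#N)cc2)c(OC)c1OC` carries cyano instead, on an aromatic carbon, para to a large group: a group of 2 heavy atoms (1 carbon, 1 nitrogen; no ring) in place of a group of 4 heavy atoms (3 carbon, 1 nitrogen; no ring), on an aromatic carbon. For the measured compounds named here, the only measured step, a 1.7-fold lower number from compound 1 to compound 2 (0.24 log units; within the scatter), concerns a different change and lies within the scatter, so it offers no direct guide. Compound 4 has no net charge, and it is expected to fall near compound 1 at 11000 nM and compound 2 at 6400 nM. The expected step, beyond the scatter, is a 4.4-fold lower number from compound 3 to compound 4 (0.64 log units; beyond the scatter). For compound 4 the estimated value is 8000 nM, with an expected range of 3000 nM to 20000 nM.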

Compound 4, half-maximal inhibitory concentration: 5400 nM
The estimate for compound 4 lay 1.5-fold (0.17 log units) above the measured number; low and high end bracket the measured number.
By their numbers in this assay, from the lowest: compounds 4, 2 and 1 (each within the scatter of the next, the first and the last beyond it); then compound 3.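

In this assay, cyano on this aromatic carbon, para to a large group, is clearly better tolerated than the charged group (a 6.5-fold lower number from compound 3 to compound 4 (0.81 log units; beyond the scatter)). The new group also sits level with the 3-fluorophenyl compound (a 1.2-fold lower number from compound 2 to compound 4 (0.07 log units; within the scatter)) and shows a modest edge over the 2-fluorophenyl one (a 2.0-fold lower number from compound 1 to compound 4 (0.31 log units; beyond the scatter)). No measurement shown accounts for these differences. Net charge and group size change together in this step, so their shares cannot be separated. Going by these compounds, whether an amine or a carboxylic acid on this carbon would match cyano stays open.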